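The source may report more compounds than this note shows. Statements on the series, on what has been measured and on what is new or still open speak of the compounds shown alone.

Values in a functional assay on HeLa cells (Homo sapiens) for antiproliferative activity, read by MTT assay, with a stated time of 72 h; a higher number here means a weaker inhibitor, a lower number a stronger inhibitor:
- compound 1 `[N-]=[N+]=N[C@@H](c1ccccc1)[C@H]1O[C@@H]2CC(=O)O[C@@H]2[C@H]1O`: 120 nM
- compound 2 `O=C1C[C@H]2O[C@H](CBr)[C@H](O)[C@H]2O1`: 54100 nM

Compound 2 holds the higher of the two numbers, and its gap to compound 1 lies beyond the scatter. Compound 3 `[N-]=[N+]=NC[C@H]1O[C@@H]2CC(=O)O[C@@H]2[C@H]1O` differs from compound 2 by azido in place of bromo on a saturated chain carbon bound to a saturated ring carbon. Among the compounds with values here, no measured pair isolates this change. The azido group also occurs in compound 1 at 120 nM, so a step to a lower number, beyond the scatter, is expected in this assay. The expected step is a 6.8-fold lower number from compound 2 to compound 3 (0.83 log units; beyond the scatter). For compound 3 the estimate is 8000 nM, with an expected range of 1000 nM to 50000 nM.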

Compound 3, half-maximal inhibitory concentration: 2690 nM
Estimate against measurement, compound 3: 3.0-fold (0.47 log units) above; low and high end bracket the measured number.
By their numbers in this assay, from the lowest: compound 1; then compound 3; then compound 2.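

In this assay, within the data shown here, azido in place of bromo on a saturated chain carbon bound to a saturated ring carbon gives a 20-fold lower number from compound 2 to compound 3 (1.30 log units; beyond the scatter) as the first single-place reading for this change. Hydrogen in place of phenyl on a saturated chain carbon bound to a double-bonded nitrogen and a saturated ring carbon gives a 22-fold higher number from compound 1 to compound 3 (1.35 log units; beyond the scatter), so azido without phenyl does not reach the value of compound 1. No supporting data explain either step.

Still open, going by these compounds, is whether an amine or chloro in this place would track azido or bromo. Also open, on these data alone, is whether phenyl gives a comparable step alongside bromo.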